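The compounds below may be only part of what the source reports. "The series", "measured", "known", "first", "only" and "open" are said of these compounds alone.

Measured so far in a functional assay on the whole organism (Tail, strain ICR) with Mus musculus as the target, in the tail flick test, with a stated time of 120 min, at a dose of 25 umol/kg by the oral route; on this read-out higher numbers stand for a stronger effect at the one dose given and lower numbers for a weaker effect:
- compound 1 `O=C(CN(c1ncnc2c1ncn2C1CCCCO1)C1CC1)N[C@@H](CO)C(=O)OCc1ccccc1` gives 29.2%
- compound 2 `NC(=O)CC[C@H](NC(=O)CN(c1nc(Cl)nc2[nH]cnc12)C1CC1)C(=O)O` gives 17.8%
- compound 3 `NC(=O)CC[C@H](NC(=O)CN(c1nc(Cl)nc2[nH]cnc12)C1CC1)C(=O)OCc1ccccc1` gives 36%

Compound 2 stands lowest of the three numbers in this assay. Compound 1 sits nearest to it, beyond the scatter above; compound 3 sits furthest, also beyond the scatter. Among the compounds with values here, the only step between measured compounds that differ in one place is a number 18.2 percentage points higher from compound 2 to compound 3 (beyond the scatter), brought about by benzyl in place of hydrogen on an oxygen next to a carbonyl group.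

Compound 4 `O=C(O)CNC(=O)CN(c1nc(Cl)nc2[nH]cnc12)C1CC1` is the next compound for this assay. It differs from compound 2 by hydrogen in place of 2-carbamoylethyl on a saturated chain carbon bound to an amide-type nitrogen and a carbonyl carbon. Within the data shown here, none of the measured steps bears on this change directly: the step from compound 2 to compound 3 alters the ester end of the molecule and leaves the 2-carbamoylethyl group in place, so it gives no guidance on what its removal does. Among the measured compounds shown here, with no comparable step in hand, no step beyond the scatter is expected in this assay, in either direction.

Compound 4 is therefore expected to give about 18% in this assay, with a range from 5% to 35%. The step of a number 0.2 percentage points higher from compound 2 to compound 4 (within the scatter) is expected to stay within the usual scatter.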

Compound 4, a percentage reported as activity, at one dose (the size of the read-out at that dose, not a potency): 19.8%
The estimate for compound 4 lay 1.8 percentage points below the measured number, within the range that was stated.
By their numbers in this assay, from the lowest: compounds 2, 4, 1 and 3 (each within the scatter of the next, the first and the last beyond it).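

In this assay, hydrogen in place of 2-carbamoylethyl on a saturated chain carbon bound to an amide-type nitrogen and a carbonyl carbon gives a number 2 percentage points higher from compound 2 to compound 4 (within the scatter) and thus no change that can be told from the scatter. Within the data shown here, this is the first reading at this position, since the earlier step of a number 18.2 percentage points higher from compound 2 to compound 3 (beyond the scatter) concerned the ester end and left the 2-carbamoylethyl group in place; among the free acids, the 2-carbamoylethyl group can therefore go without a step beyond the scatter. No supporting measurement bears on this result or accounts for it.

From the compounds shown here alone, it remains open whether a benzyl ester of compound 4 would repeat the step seen on the ester end of compound 2, and whether a methyl group, a longer alkyl chain or an amine-bearing chain at this carbon would read apart from hydrogen and 2-carbamoylethyl. Going by these compounds, each reading is also the size of the effect at one dose, so the potency of compound 2 and compound 4 stays open.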